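Working notes: the step from compound 3 to compound 4

The source may hold more compounds than are shown below. What is called first, only, known or untested is meant among the compounds shown, and "the series" means these compounds.

Measured in a functional assay on K562 cells (Homo sapiens) for inhibition, read by trypan blue exclusion, with a stated time of 72 h; a lower number here means a stronger inhibitor, a higher number a weaker inhibitor:
- compound 1 `Cn1c(=O)c(S(=O)(=O)c2ccc(F)cc2F)cc2cnc(Nc3ccc4[nH]c(C(=O)O)cc4c3)nc21`: 10000 nM
- compound 2 `COC(=O)Cn1c(=O)c(S(=O)(=O)c2ccc(F)cc2F)cc2cnc(Nc3ccc4[nH]ccc4c3)nc21`: 5000 nM
- compound 3 `Cn1c(=O)c(S(=O)(=O)c2ccc(F)cc2)cc2cnc(Nc3ccc4occc4c3)nc21`: 5000 nM

Compound 3 gives 5000 nM, level with compound 2 at 5000 nM. Compound 1, at 10000 nM, lies within the scatter of both, so no order can be drawn among the three. Within the data shown here, these compounds differ from one another in more than one place, so no measured pair isolates a single change.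

The next compound is compound 4 `Cn1c(=O)c(S(=O)(=O)c2ccc(F)cc2)cc2cnc(Nc3ccc4cc[nH]c4c3)nc21`. It carries 1H-indol-6-yl in place of 1-benzofuran-5-yl on a nitrogen on an aromatic ring. The same difference, cut one bond further out, reads (1-benzofuran-5-yl)amino to (1H-indol-6-yl)amino.

The data hold no direct measure of this change in this assay. Among the measured compounds shown here, the only guide is the narrow spread of the series, with compound 3 at 5000 nM as the starting point. No shift beyond the scatter is therefore expected. The expected step is a 1.3-fold lower number from compound 3 to compound 4 (0.10 log units; within the scatter), an estimate that stays within the scatter. For compound 4 the estimated value is 4000 nM, with an expected range of 900 nM to 10000 nM.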

Compound 4, half-maximal inhibitory concentration: 10000 nM
Compound 4: the middle estimate sits 2.5-fold (0.40 log units) below what was measured; the measured number falls inside the stated range.
By their numbers in this assay, from the lowest: compounds 2, 3, 1 and 4 (each within the scatter of the next).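

In this assay, 1H-indol-6-yl in place of 1-benzofuran-5-yl on a nitrogen on an aromatic ring gives a 2.0-fold higher number from compound 3 to compound 4 (0.30 log units; within the scatter) and is the only comparison among the compounds shown that isolates one place. At this position, then, the exchange of a benzofuran for an indole group of the same heavy-atom count, which also goes from 0 hydrogen-bond donors and 1 hydrogen-bond acceptor to 1 hydrogen-bond donor and 0 hydrogen-bond acceptors, leaves the read-out within the scatter, and compound 4 at 10000 nM does not separate from compound 3. No supporting measurement is available to explain this step or to assign it to any feature of either group.

Among these compounds, the single step changes both the hetero atom and the point of attachment, so the share of each remains unresolved. Also open, on these data alone, is whether a phenyl ring carrying a piperazine, placed on the same nitrogen of the shared core, would give a step beyond the scatter in this assay and so show that this position can move the number at all.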